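Swapping trifluoromethyl for chloro on the triazole aryl arm

The source may hold more compounds than are shown below. What is called first, only, known or untested is meant among the compounds shown, and "the series" means these compounds.

Three analogues of one shared core have been tested in a functional assay on HL-60 cells (Homo sapiens) for cytotoxicity, read by MTT assay, with a stated time of 4 days; on this read-out higher numbers stand for weaker inhibition and lower numbers for stronger inhibition. Compound 1 `C=C1C[C@]23C[C@@]1(O)CC[C@H]2c1cc(Br)c(O)c(C)c1[C@@H]3Cn1cc(-c2ccccc2)nn1` carries a phenyl on the triazole; in this assay compound 1 gives only a limit, > 20000 nM. Compound 2 `C=C1C[C@]23C[C@@]1(O)CC[C@H]2c1cc(Br)c(O)c(C)c1[C@@H]3Cn1cc(-c2ccccn2)nn1` carries a pyridin-2-yl; in this assay compound 2 also gives only a limit, > 20000 nM. Compound 3 `C=C1C[C@]23C[C@@]1(O)CC[C@H]2c1cc(Br)c(O)c(C)c1[C@@H]3Cn1cc(-c2ccc(C(F)(F)F)cc2)nn1` carries a 4-(trifluoromethyl)phenyl, and in this assay compound 3 gives 7380 nM. Among the measured compounds shown here, that is the only real number here, since two of the three results sit at the limit of > 20000 nM in this assay, at which 2 of the 3 values shown sit. The steps into compound 3 were an at least 2.7-fold lower number from compound 1 to compound 3 (0.43 log units; beyond the scatter) and an at least 2.7-fold lower number from compound 2 to compound 3 (0.43 log units; beyond the scatter). Compound 4 `C=C1C[C@]23C[C@@]1(O)CC[C@H]2c1cc(Br)c(O)c(C)c1[C@@H]3Cn1cc(-c2ccc(Cl)cc2)nn1` differs from compound 3 by chloro in place of trifluoromethyl on an aromatic carbon. Neither measured step swaps one substituent for another on that phenyl, so the size of this change is not anchored. Compound 4 is estimated at 10000 nM, with a range from 4000 nM to 25000 nM. That estimate means an expected 1.4-fold higher number from compound 3 to compound 4 (0.13 log units; within the scatter).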

Compound 4, half-maximal inhibitory concentration: 5590 nM
For compound 4 the middle estimate is 1.8-fold (0.25 log units) above the measured one, within the range that was stated.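

Chloro and trifluoromethyl cannot be told apart on this aromatic carbon, with a 1.3-fold lower number from compound 3 to compound 4 (0.12 log units; within the scatter), so compound 3 is no longer the only analogue with a measured value. Chloro in place of hydrogen also gives a step beyond the scatter, an at least 3.5-fold lower number from compound 1 to compound 4 (0.55 log units; beyond the scatter), and the 4-chlorophenyl arm compares in the same way with pyridin-2-yl, an at least 3.5-fold lower number from compound 2 to compound 4 (0.55 log units; beyond the scatter). Both of those sizes are minimums, since each starting compound gave only a limit: the limit of > 20000 nM in this assay, at which 2 of the 4 values shown sit.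

The compounds shown leave open whether an amine or a carboxylic acid on this carbon would give a measured value as well. They also leave open how far the true values of compound 1 and compound 2 lie beyond their limits.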